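A few compounds are considered here, and "the series" means these few. Any claim that something is new, unique, unknown or untested is made for them only; others in the source may bear on it.

Measured compounds:
Compound 1 `CC(C)=CC[C@@H](OC(=O)c1ccoc1)C1=CC(=O)c2c(O)ccc(O)c2C1=O` — in a functional assay on HeLa cells (Homo sapiens) for cytotoxicity, read by MTT assay (on this read-out higher numbers stand for weaker inhibition and lower numbers for stronger inhibition), compound 1 gives > 100000 nM, which is a limit of the assay and not a number.
Compound 2 `CC(=O)OCCO[C@H](CC=C(C)C)C1=CC(=O)c2c(O)ccc(O)c2C1=O` — in this assay compound 2 gives 41500 nM.
Compound 3 `CC[C@@](C)(O)CC(=O)O[C@H](CC=C(C)C)C1=CC(=O)c2c(O)ccc(O)c2C1=O` — in this assay compound 3 gives 17900 nM.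

Compound 3 holds the lowest of the two numbers; the nearest is compound 2, with a 2.3-fold lower number from compound 2 to compound 3 (0.37 log units; beyond the scatter). Compound 4 `CC(C)=CC[C@@H](OC(=O)C1CCCCO1)C1=CC(=O)c2c(O)ccc(O)c2C1=O` differs from compound 3 by oxan-2-yl in place of 2-hydroxy-2-methylbutyl on a carbonyl carbon. For the measured compounds named here, the one measured step at this carbonyl carbon is an at least 5.5-fold lower number from compound 1 to compound 3 (0.74 log units; beyond the scatter), where furan-3-yl left and 2-hydroxy-2-methylbutyl entered; the change to compound 4 goes the other way, bringing in the ring oxan-2-yl, while compound 1 itself sits at a limit (the limit of > 100000 nM in this assay, at which 1 of the 3 values shown sits). A modest rise in the number is therefore expected, a 2.2-fold higher number from compound 3 to compound 4 (0.35 log units; beyond the scatter). Compound 4 is estimated at 40000 nM, between 15000 nM and 100000 nM.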

Compound 4, half-maximal inhibitory concentration: > 100000 nM
Compound 4: a limit, no number; the forecaster's own chance of this, stated with the estimate: 25%; at least 2.5-fold (0.39 log units) between middle value and limit.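

The change on this carbonyl carbon swaps 2-hydroxy-2-methylbutyl for oxan-2-yl, which has the same heavy-atom count, yet it gives an at least 5.5-fold higher number from compound 3 to compound 4 (0.74 log units; beyond the scatter). Against the 2-acetoxyethyl on the oxygen, (oxan-2-yl)carbonyl gives an at least 2.4-fold higher number from compound 2 to compound 4 (0.38 log units; beyond the scatter). Compound 1 and compound 4, the two with a ring on this carbonyl carbon, both sit at a limit, so the step between them cannot be read: the limit of > 100000 nM in this assay, at which 2 of the 4 values shown sit.

This change brings in the ring and removes the hydrogen-bond donor together, and the compounds shown cannot separate the two. A plain 2-methylbutyl chain, or an oxan-2-yl ring carrying a hydroxyl, would tell them apart.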